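A few compounds are considered here, and "the series" means these few. Any claim that something is new, unique, unknown or untested is made for them only; others in the source may bear on it.

In a functional assay on L5178Y cells (Mus musculus) for inhibition, read by MTT assay, with a stated time of 24 h (a higher number here means a weaker inhibitor, a lower number a stronger inhibitor), compound 1 `Oc1ccc([C@@H]2C/C(=N\Nc3ccccc3)c3c(O)cc(O)cc3O2)cc1` gives >= 11300 nM, which is a limit and not a number. Compound 2 `Oc1ccc([C@@H]2C/C(=N\Nc3ccc(Br)cn3)c3c(O)cc(O)cc3O2)cc1` gives >= 11300 nM, also a limit. Compound 3 `O=C(N/N=C1\C[C@@H](c2ccc(O)cc2)Oc2cc(O)cc(O)c21)c1ccco1` gives >= 11300 nM, again only a limit. The series therefore stands at the limit of >= 11300 nM in this assay, at which 3 of the 3 values shown sit.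

Compound 4 `CN(C)C(=S)N/N=C1\C[C@@H](c2ccc(O)cc2)Oc2cc(O)cc(O)c21` differs from compound 3 on an amine nitrogen: a group of 5 heavy atoms (3 carbon, 1 nitrogen, 1 sulfur; no ring) in place of a group of 7 heavy atoms (5 carbon, 2 oxygen; one five-membered aromatic ring with 1 hetero atom), on an amine nitrogen.

The steps bearing on this change are a step that the two limits leave unreadable from compound 1 to compound 3 and a step that the two limits leave unreadable from compound 2 to compound 3, and a step that the two limits leave unreadable from compound 1 to compound 2 gives no size either. With no readable size or direction to carry over, the expected change in this assay is a step that the limit leaves unreadable from compound 3 to compound 4, an estimate that supports nothing beyond the scatter. Compound 4 is expected at 14000 nM, within an estimated range of 5000 nM to 40000 nM.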

Compound 4, half-maximal inhibitory concentration: >= 11300 nM
Compound 4: no number, only a limit (the forecaster's own chance of this, stated with the estimate: 60%); the middle value lies beyond the limit too.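

Compound 4 gives >= 11300 nM, which is only a limit, and its steps from compound 1, compound 2 and compound 3 cannot be read. The compounds shown leave open whether any group on the amine nitrogen changes potency in this assay, because all share one limit: the limit of >= 11300 nM in this assay, at which 4 of the 4 values shown sit.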